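A few compounds are considered here, and "the series" means these few. Any claim that something is new, unique, unknown or untested is made for them only; others in the source may bear on it.

Measured so far in an in vitro functional assay on HEK293-A cells for positive allosteric modulation of metabotropic glutamate receptor 5 (Homo sapiens), read by FLIPR and calcium flux; a higher number here means that more compound is needed for the effect, a lower number that less compound is needed:
compound 1 `Cc1cccc(-c2noc(C3CC(=O)N(c4ccc(Cl)cc4)C3)n2)c1` — 170 nM
compound 2 `Cc1ccc(N2CC(c3nc(-c4ccccc4)no3)CC2=O)cc1` — 384 nM
compound 3 `Cc1cccc(-c2noc(C3CC(=O)N(c4ccc(C)c(Cl)c4)C3)n2)c1` — 240 nM

Compound 3 stands second highest of the three numbers; its nearest neighbour is compound 1 and its furthest is compound 2, and both gaps are within the scatter, so no order among the three can be read. Going by the values given here, the only measured step, a 1.4-fold higher number from compound 1 to compound 3 (0.15 log units; within the scatter), was within the scatter.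

Compound 4 `Cc1ccc(N2CC(c3nc(-c4cccc(C)c4)no3)CC2=O)cc1` differs from compound 3 by hydrogen in place of chloro on an aromatic carbon. Among the compounds with values here, no measured step shows this change itself; compound 2 carries the 4-methylphenyl group but differs elsewhere, so its value bears only loosely. Within the data shown here, with compound 3 at 240 nM and the one known step within the scatter, compound 4 is expected to show a 1.3-fold higher number from compound 3 to compound 4 (0.10 log units; within the scatter), no step beyond the scatter. Compound 4 is estimated at 300 nM, range 120 nM to 750 nM.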

Compound 4, half-maximal effective concentration: 1300 nM
For compound 4 the middle estimate is 4.3-fold (0.64 log units) below the measured one; the whole stated range lies below it.
By their numbers in this assay, from the lowest: compounds 1, 3 and 2 (each within the scatter of the next, the first and the last beyond it); then compound 4.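

In this assay, going by these compounds alone, the chloro of the 3-chloro-4-methylphenyl group matters: hydrogen in its place gives the first single change beyond the scatter on this ring, a 5.4-fold higher number from compound 3 to compound 4 (0.73 log units; beyond the scatter). Methyl in place of chloro gives a 7.6-fold higher number from compound 1 to compound 4 (0.88 log units; beyond the scatter), and methyl in place of hydrogen on an aromatic carbon gives a 3.4-fold higher number from compound 2 to compound 4 (0.53 log units; beyond the scatter), so the chloro compounds 1 and 3 sit lowest, though compound 2, without chloro, lies within the scatter of compound 3. Nothing available explains these steps.

Open, from the compounds shown here alone, is whether fluoro, methoxy or nitrile in place of that chloro would hold the number of compound 3.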